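Hydroxy-to-methoxy exchange on two related lactone pairs

The source may report more compounds than this note shows. Statements on the series, on what has been measured and on what is new or still open speak of the compounds shown alone.

Measured so far in a functional assay on HL-60 cells (Homo sapiens) for cytotoxicity, read by WST assay, with a stated time of 48 h; on this read-out lower numbers stand for an effect already at smaller amounts and higher numbers for an effect only at larger amounts of compound:

compound 1 `O=C1OC[C@H](Cc2ccccc2)[C@H]1Cc1ccccc1O`: 83000 nM
compound 2 `COc1ccccc1C[C@H]1C(=O)OC[C@@H]1Cc1ccccc1`: 79000 nM
compound 3 `O=C1OC[C@H](Cc2ccccc2O)[C@H]1Cc1ccc(Cl)c(Cl)c1`: 33000 nM

Three compounds have numbers; compound 4 `COc1ccccc1C[C@H]1COC(=O)[C@@H]1Cc1ccc(Cl)c(Cl)c1` has not yet been run in this assay.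

Compound 1 and compound 2 differ by one change, (methyl in place of hydrogen on an oxygen on an aromatic ring). Its effect in this assay is a 1.1-fold lower number from compound 1 to compound 2 (0.02 log units; within the scatter), so the pair reads as the same within the usual scatter of the read-out.

Compound 3 carries a different core than compound 1; the difference between the two cores is not broken down here. In this assay compound 3 gives the lowest of the three numbers, and both of its steps to compound 1 and to compound 2 lie beyond the scatter.

Compound 4 stands to compound 3 exactly as compound 2 stands to compound 1: methyl in place of hydrogen on an oxygen on an aromatic ring. The place of the change is the same in both pairs, an oxygen on an aromatic ring whose other neighbour is an aromatic carbon, so this is the same change made on a second core.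

Among the measured compounds shown here, the one measured instance of this change, from compound 1 to compound 2, moved the number by an amount inside the scatter. Carrying that over, the step from compound 3 to compound 4 in this assay is expected to be a 1.0-fold lower number from compound 3 to compound 4 (0.01 log units; within the scatter), resting on a 1.1-fold lower number from compound 1 to compound 2 (0.02 log units; within the scatter). Compound 4 is therefore estimated to land near compound 3, at 32000 nM, with a likely range from 12000 nM to 80000 nM.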

Compound 4, half-maximal effective concentration: 14000 nM
Beside the measured number, compound 4's estimate is 2.3-fold (0.36 log units) above it; measured number inside the range.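

Among the compounds shown here, on the core of compound 3, the exchange of hydroxy for methoxy gives in this assay a 2.4-fold lower number from compound 3 to compound 4 (0.37 log units; beyond the scatter), a modest step, whereas the earlier instance of the same change, a 1.1-fold lower number from compound 1 to compound 2 (0.02 log units; within the scatter), produced no step that can be told from the scatter. Taken side by side, the two instances cannot be separated, so the series gives no sign that the outcome of this change depends on the core: the same change on two cores in this assay, a 1.1-fold lower number (0.02 log units; within the scatter) from compound 1 to compound 2 and a 2.4-fold lower number (0.37 log units; beyond the scatter) from compound 3 to compound 4, 2.2-fold (0.35 log units) apart, within the scatter of two such steps. For the compounds shown here, this supports carrying the change from one of these cores to the other as a small step at most, but it does not show that the step has the same size on both cores, nor that methoxy reliably gives a lower number than hydroxy, since only one of the two pairs moves beyond the scatter.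

The compounds shown leave open whether a longer chain on that oxygen, such as ethyl or propyl, or an amine or a carboxylic acid in place of the hydroxy group, would behave as methoxy does in this assay. They also leave open whether the comparison made on these two cores holds on any further core.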